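Swapping methyl for methoxycarbonyl in a flat series

A few compounds are considered here, and "the series" means these few. Any claim that something is new, unique, unknown or untested is made for them only; others in the source may bear on it.

Values so far in a functional assay on MOLT-4 cells (Homo sapiens) for cytotoxicity, read by CCK-8 assay, with a stated time of 24 h (a lower number here means a stronger inhibitor, a higher number a weaker inhibitor), are:
Compound 1 `C=CC(=O)N1C(=O)CC(c2ccc(C)cc2)Sc2ccccc21` gives 87600 nM
Compound 2 `C=CC(=O)N1C(=O)CC(c2ccccc2C(F)(F)F)Sc2ccccc21` gives 84400 nM
Compound 3 `C=CC(=O)N1C(=O)CC(c2ccc(-c3ccccc3)cc2)Sc2ccccc21` gives 97500 nM

Compound 1 lies within the usual scatter of repeat measurements from both compound 2 and compound 3, so no order between compound 1 and either of them can be read from these numbers.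

The next compound, compound 4 `C=CC(=O)N1C(=O)CC(c2ccc(C(=O)OC)cc2)Sc2ccccc21`, keeps the core of compound 1 and alters one group. The change is methoxycarbonyl in place of methyl on an aromatic carbon, para to a large group (methoxycarbonyl in place of methyl on an aromatic carbon).

Among the measured compounds shown here, only one measured step replaces this same methyl, and it is a 1.1-fold higher number from compound 1 to compound 3 (0.05 log units; within the scatter) with phenyl as the entering group. A much bigger group therefore left the number in this assay within the scatter. For the measured compounds named here, that single step is thin evidence, and no measured compound carries an ester. Resting on the step to compound 3, no change beyond the scatter is expected. The estimate is a 1.0-fold higher number from compound 1 to compound 4 (0.01 log units; within the scatter) in this expectation. Compound 4 is expected at 90000 nM with an estimated range from 50000 nM to 160000 nM in this assay's repeat measurements.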

Compound 4, half-maximal inhibitory concentration: 79600 nM
Compound 4: middle estimate off by 1.1-fold (0.05 log units), on the high side; measured number inside the range.
By their numbers in this assay, from the lowest: compounds 4, 2, 1 and 3 (each within the scatter of the next).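

In this assay the methoxycarbonyl group, the only ester among these compounds, brings oxygen atoms and two hydrogen-bond acceptors to a place where methyl has none, yet the result is a 1.1-fold lower number from compound 1 to compound 4 (0.04 log units; within the scatter) and the number does not move beyond the scatter. Compared with the larger phenyl group, the same ester gives a 1.2-fold lower number from compound 3 to compound 4 (0.09 log units; within the scatter), so methyl, phenyl and methoxycarbonyl, three quite different groups on this aromatic carbon, cannot be placed in any order by these numbers, and the flat picture that earlier rested on a single step now rests on three compounds. No supporting measurement is available to explain this flatness.

The compounds shown leave open whether a group with a net charge at this same place, such as a carboxylic acid or an amine, would move the number beyond the scatter, as all the groups compared here carry no net charge. They also leave open whether a change to the shared core itself, not to this group, would shift the number in this assay by more.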